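Hexyl in Place of Hydrogen: Expected Cytotoxicity of Compound 4

The source may hold more compounds than are shown below. What is called first, only, known or untested is meant among the compounds shown, and "the series" means these compounds.

Measured compounds:
compound 1, `COc1ccc(OC)c2c1C(=O)C=C(CO)C2=O`, 0.524 ug/mL
compound 2, `CCCCCCCC(O)C1=CC(=O)c2c(OC)ccc(OC)c2C1=O`, 1.04 ug/mL
compound 3, `COc1cc(CO)c(OC)c2c1C(=O)C=CC2=O`, 0.062 ug/mL

In a functional assay on L1210 cells (Mus musculus) for cytotoxicity (a higher number here means that more compound is needed for the effect, a lower number that less compound is needed), compound 1 holds the second highest of the three numbers. Compound 2 lies nearest to it, with the difference between the two inside the scatter, while compound 3 lies furthest, with a lower number that goes beyond the scatter.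

The unmeasured compound 4 is `CCCCCCC(O)C1=CC(=O)c2c(OC)ccc(OC)c2C1=O`. It differs from compound 1 by one change: hexyl in place of hydrogen on a saturated chain carbon bound to a double-bonded ring carbon and an oxygen on a saturated carbon.

Going by the values given here, one measured step bears directly on this change, a 2.0-fold higher number from compound 1 to compound 2 (0.30 log units; within the scatter), where heptyl enters at the same place. That step stayed within the scatter. Compound 4 carries a chain of the same kind at the same place, so the expected step is of comparable size, a 1.7-fold higher number from compound 1 to compound 4 (0.23 log units; within the scatter), and is not expected to go beyond the scatter in this assay. Compound 4 is therefore estimated at 0.9 ug/mL, with a range from 0.4 ug/mL to 2 ug/mL.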

Compound 4, concentration for half-maximal effect: 0.732 ug/mL
For compound 4 the middle estimate is 1.2-fold (0.09 log units) above the measured one; measured number inside the range.
By their numbers in this assay, from the lowest: compound 3; then compounds 1, 4 and 2 (each within the scatter of the next).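

In this assay, hexyl in place of hydrogen on the saturated chain carbon (a 1.4-fold higher number from compound 1 to compound 4 (0.15 log units; within the scatter)) stays within the scatter, so a second chain at this place now gives the same reading as heptyl did. Going by these compounds alone, the new compound also allows the chain itself to be compared for the first time: hydrogen in place of methyl at the far end of the chain (a 1.4-fold lower number from compound 2 to compound 4 (0.15 log units; within the scatter)) is within the scatter too, and the hexyl and heptyl compounds cannot be told apart in this test. Nothing available explains these steps.

The compounds shown leave open whether a longer chain, such as decyl, at this place would give a step beyond the scatter. Also open, as far as these compounds go, is what an amine in place of the oxygen on the saturated carbon would do in this assay with the same chain in place.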